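From Hydroxamic Acid to Aminoanilide on a Shared Core

The source may report more compounds than this note shows. Statements on the series, on what has been measured and on what is new or still open speak of the compounds shown alone.

Compound 1 `O=C(NO)c1ccc(-c2nnc(Cc3cccc4ccccc34)o2)cc1` and compound 2 `O=C(/C=C/c1ccc(-c2nnc(Cc3cccc4ccccc34)o2)cc1)NO` share one core and differ in a single place. In an assay on isolated protein for inhibition of histone deacetylase 4 (Homo sapiens), read by fluorescence, with a stated time of 15 min (a higher number here means a weaker inhibitor, a lower number a stronger inhibitor), compound 1 gives > 20000 nM, a limit of the assay rather than a number. Compound 2 gives > 20000 nM in this assay, again a limit. The step that the two limits leave unreadable from compound 1 to compound 2 therefore cannot be read, since both values sit at the limit of > 20000 nM in this assay, at which 2 of the 2 values shown sit. Compound 3 `Nc1ccccc1NC(=O)/C=C/c1ccc(-c2nnc(Cc3cccc4ccccc34)o2)cc1` has not yet been measured; it carries 2-aminophenyl in place of hydroxy on an amide-type nitrogen. For the measured compounds named here, no measured step bears on this change, so its size cannot be read from the data. Compound 3 is expected to give 30000 nM in this assay, within 10000 nM to 100000 nM. The expected step is a step that the limit leaves unreadable from compound 2 to compound 3, most likely reported as a limit again.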

Compound 3, half-maximal inhibitory concentration: > 20000 nM
Compound 3 was reported as a limit; the forecaster's own chance of this, stated with the estimate: 85%; the middle value does not contradict the limit.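

Compound 3 also sits at a limit, so the steps linking compound 1, compound 2 and compound 3 cannot be read: the limit of > 20000 nM in this assay, at which 3 of the 3 values shown sit.

The compounds shown leave open how strongly each one inhibits in this assay and whether changing hydroxycarbamoyl to (2-aminophenyl)carbamoyl makes any difference.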